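This account rests on a few compounds, and the source may have more. Where it says the series, first, only, none or still open, it means among the compounds named here.

Measured compounds:
compound 1 `CC/C(=C(/c1ccc(/C=C/C(=O)O)cc1)c1ccc(O)nc1)c1ccccc1` — a functional assay on MCF7 cells (Homo sapiens) for cytotoxicity, read by CellTiter-Glo, with a stated time of 5 days; on this read-out higher numbers stand for weaker inhibition and lower numbers for stronger inhibition: "not determined" (no result reported)
compound 2 `CC/C(=C(/c1ccc(/C=C/C(=O)O)cc1)c1ccc2[nH]ncc2c1)c1ccccc1` — this assay: 6 nM

Compound 1 has no single number in this assay, so where it stands cannot be stated. Going by the values given here, compound 2 gives 6 nM in this assay, the only number so far. Compound 3 `CC/C(=C(/c1ccc(/C=C/C(=O)O)cc1)c1cccc2[nH]ncc12)c1ccccc1` differs from compound 1 in one place: 1H-indazol-4-yl in place of 6-hydroxypyridin-3-yl on a double-bonded chain carbon bound to an aromatic carbon and a double-bonded chain carbon. Among the compounds with values here, no measured step exists for this pair, so the direction of the change is open; a step of modest size, within or just beyond the usual scatter, seems as likely as any. Compound 3 is expected to give about 15 nM in this assay, between 4 nM and 60 nM.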

Compound 3, half-maximal inhibitory concentration: 21 nM
Beside the measured number, compound 3's estimate is 1.4-fold (0.15 log units) below it; low and high end bracket the measured number.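

In this assay, the attachment point of the indazole at this double-bonded chain carbon changes the read-out: 1H-indazol-4-yl in place of 1H-indazol-5-yl gives a 3.5-fold higher number from compound 2 to compound 3 (0.54 log units; beyond the scatter). Going by these compounds alone, the series so far therefore responds to where the same group is attached, not only to which group is present. No measurement available here accounts for this step.

The step from compound 1 to compound 3 cannot be read. Open, from the compounds shown here alone, are a 1H-indazol-6-yl or 4-hydroxyphenyl group at this place, and an amide in place of the carboxylic acid.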